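The compounds below may be only part of what the source reports. "The series", "measured", "known", "first", "only" and "open" are said of these compounds alone.

Measured in a functional assay on CEM-DNR-bulk cells (Homo sapiens), read by MTT assay, with a stated time of 72 h; on this read-out higher numbers stand for weaker inhibition and lower numbers for stronger inhibition:
- compound 1 `CSc1ncnc2c1c(-c1ccsc1)cn2[C@@H]1O[C@H](CO)[C@@H](O)[C@H]1O`: > 20000 nM
- compound 2 `Cc1ncnc2c1c(-c1ccoc1)cn2[C@@H]1O[C@H](CO)[C@@H](O)[C@H]1O`: > 20000 nM

Compound 2 gives > 20000 nM, which is a limit and not a number. Compound 1 gives > 20000 nM, also a limit. Among the measured compounds shown here, the two measured compounds therefore share one position, (the limit of > 20000 nM in this assay, at which 2 of the 2 values shown sit), and no measured step is available in this assay.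

Compound 3 `Cc1ncnc2c1c(-c1ccsc1)cn2[C@@H]1O[C@H](CO)[C@@H](O)[C@H]1O` carries thiophen-3-yl in place of furan-3-yl on an aromatic carbon of the shared core: thiophen-3-yl in place of furan-3-yl on an aromatic carbon.

No change beyond the scatter is expected in this assay, since compound 1, which also bears thiophen-3-yl, shows > 20000 nM. The estimated step is a number no higher from compound 2 to compound 3 (the limit leaves the size open), with no direction favoured. A report of only a limit is the likeliest outcome. For compound 3 the expected value is 20000 nM, with an estimated range of 7000 nM to 50000 nM.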

Compound 3, half-maximal inhibitory concentration: 8560 nM
The estimate for compound 3 lay 2.3-fold (0.37 log units) above the measured number; low and high end bracket the measured number.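

In this assay, among the compounds shown here, compound 3 gives the first number in this set rather than a limit, showing that the read-out can respond to changes on this core. Thiophen-3-yl in place of furan-3-yl on the aromatic carbon brings an at least 2.3-fold lower number from compound 2 to compound 3 (0.36 log units; beyond the scatter), while methyl in place of methylsulfanyl brings an at least 2.3-fold lower number from compound 1 to compound 3 (0.36 log units; beyond the scatter). Thiophen-3-yl alone does not secure a number, since compound 1 also bears it and reports only a limit, and the same holds for methyl, which compound 2 bears; among these compounds, only the combination in compound 3 gives a number, and both steps start from a limit, so their full size stays open: the limit of > 20000 nM in this assay, at which 2 of the 3 values shown sit.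

From the compounds shown here alone, it remains open whether an amine in place of methyl, or phenyl in place of thiophen-3-yl, would lower the number further. These compounds also leave open how much of the step belongs to each group.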